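The source may hold more compounds than are shown below. What is called first, only, known or untested is meant among the compounds shown, and "the series" means these compounds.

Compound 2 `Cc1cc(Oc2cccc(Cl)c2)c(S(C)(=O)=O)cc1C(=O)N=C(N)N` and compound 1 `Cc1cc(Br)c(S(C)(=O)=O)cc1C(=O)N=C(N)N` share a core carrying an acylguanidine and a methylsulfonyl group, and they differ only in what sits on one aromatic carbon. In a functional assay for inhibition of sodium/hydrogen exchanger (Oryctolagus cuniculus) (a higher number here means a weaker inhibitor, a lower number a stronger inhibitor), compound 1 gives 12 nM, and in this assay compound 2 gives 21 nM. Among the compounds with values here, the only measured step, a 1.8-fold higher number from compound 1 to compound 2 (0.24 log units; within the scatter), is small. Compound 2 stands at one end of these two numbers, with compound 1 the nearest to it and within the scatter, so nothing separates the pair.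

Compound 3 `Cc1ccc(S(C)(=O)=O)cc1C(=O)N=C(N)N` has not yet been measured in this assay. It differs from compound 2 in this way: hydrogen in place of 3-chlorophenoxy on an aromatic carbon. The place is ortho to a methylsulfonyl group and para to a group of 6 heavy atoms. Within the data shown here, only the step from compound 1 to compound 2 bears on this change, and it covers an exchange of one group for another at this carbon, not the removal of the group altogether; no measured pair covers that. Compound 3 is therefore expected to show a modest step upward, a 1.9-fold higher number from compound 2 to compound 3 (0.28 log units; within the scatter), with wide uncertainty. Compound 3 is estimated at 40 nM, within a range from 12 nM to 150 nM.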

Compound 3, half-maximal inhibitory concentration: 150 nM
Beside the measured number, compound 3's estimate is 3.8-fold (0.57 log units) below it; the measured number falls inside the stated range.
By their numbers in this assay, from the lowest: compounds 1 and 2 (each within the scatter of the next); then compound 3.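

The result shows that what matters at this aromatic carbon, ortho to a methylsulfonyl group, is whether a group is there at all, something the exchange of bromo for 3-chlorophenoxy could not reveal. In this assay, taking away 3-chlorophenoxy, with its 8 heavy atoms, gives a 7.1-fold higher number from compound 2 to compound 3 (0.85 log units; beyond the scatter) and is a modest change, while hydrogen in place of bromo gives a 13-fold higher number from compound 1 to compound 3 (1.10 log units; beyond the scatter) and is a large one. Compound 1 and compound 2 stay within the scatter of each other, so bromo and 3-chlorophenoxy, two very different groups, both give clearly lower numbers than hydrogen among these three compounds, and the data on hand offer no explanation for this.

What the compounds leave open is whether other groups at this carbon would do the same, for instance an amine, a methoxy group, a fluorine atom or a longer chain attached through oxygen. They also leave open whether the rise on losing the group would be of similar size on a core without the methyl group that compound 1, compound 2 and compound 3 all carry.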